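A few compounds are considered here, and "the series" means these few. Any claim that something is new, unique, unknown or untested is made for them only; others in the source may bear on it.

Measured compounds and their numbers in a physicochemical assay for lipophilicity, read by HPLC, at pH 7.4; on this read-out higher numbers stand for higher lipophilicity and lower numbers for lower lipophilicity:
- compound 1, `Cc1ccnc([C@@H](C)Oc2cc3oc(=O)n(CCC(=O)O)c3cc2Cl)c1`, gives 2.15
- compound 2, `C[C@@H](Oc1cc2sc(=O)n(CCC(=O)O)c2cc1Cl)c1ccccn1`, gives 1.81
- compound 3, `CCc1cc2oc(=O)n(CCC(=O)O)c2cc1Cl`, gives 1.94

Compound 3 sits between the other two on this assay. Among the measured compounds shown here, its number lies closest to that of compound 2 and furthest from that of compound 1, but each of these gaps is within the usual scatter of repeated measurements, so the three measured compounds cannot be told apart on the numbers so far. All three carry the same acid-bearing side chain on the shared core, and the differences among them sit on the aromatic carbon that bears the variable group.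

Compound 4, `O=C(O)CCn1c(=O)oc2cc(OCC3CCC3)c(Cl)cc21`, has not been measured in this assay. Its relation to compound 3 is cyclobutylmethoxy in place of ethyl on an aromatic carbon. For the measured compounds named here, no step between measured compounds with a change of this kind is available, so the size of the step rests on the structural change alone: the group entering is larger than the group leaving, and an increase in the number beyond the scatter is expected.

For compound 4 the estimated value in this assay is 2.9, with an expected range from 2.4 to 3.4. The expected step is a number 0.96 log units higher from compound 3 to compound 4 (beyond the scatter), upward and beyond the scatter.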

Compound 4, distribution coefficient: 2.9
The estimate for compound 4 equals the measured number at the digits printed, within the range that was stated.
By their numbers in this assay, from the lowest: compounds 2, 3 and 1 (each within the scatter of the next, the first and the last beyond it); then compound 4.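

In this assay, among the compounds shown here, cyclobutylmethoxy in place of ethyl on the aromatic carbon ortho to a chloro group gives a number 0.96 log units higher from compound 3 to compound 4 (beyond the scatter), the only comparison that isolates a change in one place, and one the earlier compounds could not supply. This position therefore tolerates a change of group that moves the read-out beyond the scatter, at least for this one pair on the shared core. The entering group differs from ethyl in three ways at once, with more heavy atoms, a four-membered non-aromatic ring of carbon only and a hydrogen-bond acceptor, and no measurement at hand says what accounts for the size of the step.

Still open is how the step divides among these features: methoxy, cyclobutyl attached directly to the aromatic carbon, or a longer chain such as butoxy at the same carbon would each help to separate them. Also open is how a primary amine or a carboxylic acid on this carbon would read in this assay, since every group shown here carries neither.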